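The source may report more compounds than this note shows. Statements on the series, on what has been measured and on what is new or still open speak of the compounds shown alone.

In an ADME assay on HEK293 cells (Homo sapiens) for cytotoxicity, read by CCK-8 assay, with a stated time of 4 days (on this read-out lower numbers stand for stronger inhibition and higher numbers for weaker inhibition), compound 1 `Oc1ccc(-c2cc(-c3ccc(O)cc3)nc(-c3ccc(O)cc3)c2)cc1` gives 790 nM and stands level, within the usual scatter, with compound 3 `Oc1ccc(-c2cc(-c3ccccc3O)cc(-c3ccc(O)cc3)n2)cc1` at 780 nM in the same test. Compound 2 `Oc1ccc(-c2cc(-c3cccc(O)c3)cc(-c3ccc(O)cc3)n2)cc1` gives > 50000 nM which is a limit of the assay and not a number.

Compound 4 `Oc1ccc(-c2cc(-c3ccc(O)cc3)nc(-c3ccccc3O)c2)cc1` has the same atoms as compound 1, joined differently: 2-hydroxyphenyl in place of 4-hydroxyphenyl on an aromatic carbon. A 2-hydroxyphenyl enters in place of a 4-hydroxyphenyl, next to the ring nitrogen.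

Among the compounds with values here, two measured steps bear on this, both made on a different aromatic carbon of the core, so they guide only indirectly. The same swap gave a 1.0-fold lower number from compound 1 to compound 3 (0.01 log units; within the scatter) and left the number in place. Putting 3-hydroxyphenyl there instead gave an at least 63-fold higher number from compound 1 to compound 2 (1.80 log units; beyond the scatter) and shows that moving one hydroxyl can have a large effect.

The closer precedent suggests no change beyond the scatter in this assay, and the expected step is a 1.5-fold higher number from compound 1 to compound 4 (0.18 log units; within the scatter) with more room towards higher numbers. The estimated value for compound 4 is 1200 nM with an expected range from 350 nM to 8000 nM in this test.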

Compound 4, half-maximal inhibitory concentration: 26300 nM
Estimate against measurement, compound 4: 22-fold (1.34 log units) below; measured number above the stated range.
By their numbers in this assay, from the lowest: compounds 3 and 1 (each within the scatter of the next); then compound 4. At a limit, above all of these: compound 2.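

In this assay, the swap to 2-hydroxyphenyl gave a 1.0-fold lower number from compound 1 to compound 3 (0.01 log units; within the scatter) on one aromatic carbon of the core, but next to the ring nitrogen it gave a 33-fold higher number from compound 1 to compound 4 (1.52 log units; beyond the scatter). The same change of group can therefore matter a great deal or hardly at all in this test, depending on where on the core it is made, so the entering group alone does not settle the outcome among these compounds. Compound 2 still carries a limit of the assay and not a number: the limit of > 50000 nM in this assay, at which 1 of the 4 values shown sits.

The compounds shown do not tell why this place responds so differently. Going by these compounds, it also stays open how this test would respond next to the ring nitrogen to a phenyl ring carrying an amine or a carboxylic acid in place of the hydroxyl.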